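The source may hold more compounds than are shown below. What is called first, only, known or untested is meant among the compounds shown, and "the series" means these compounds.

In a functional assay on HeLa cells (Homo sapiens) for antiproliferative activity, read by MTT assay, with a stated time of 24 h (on this read-out lower numbers stand for stronger inhibition and higher numbers for weaker inhibition), two compounds with a shared core have been measured so far. Among the compounds with values here, compound 1 `Cc1ccc(-c2nn(-c3ccccc3)cc2-c2nc3ccccc3n2S(=O)(=O)c2ccccc2)cc1` gives 820 nM and compound 2 `O=S(=O)(c1ccccc1)n1c(-c2cn(-c3ccccc3)nc2-c2ccc(F)cc2)nc2ccccc21` gives 680 nM so compound 2 stands level with compound 1, the only other number available. Compound 3 `O=S(=O)(c1ccccc1)n1c(-c2cn(-c3ccccc3)nc2-c2ccc(C(F)(F)F)cc2)nc2ccccc21` differs from compound 2 in a single substituent, with trifluoromethyl in place of fluoro on an aromatic carbon, para to a large group, and the difference counts as trifluoromethyl in place of fluoro on an aromatic carbon with the rest of the structure unchanged. Within the data shown here, one measured step bears on this place. It is a 1.2-fold lower number from compound 1 to compound 2 (0.08 log units; within the scatter) for fluoro in place of methyl on that aromatic carbon, and it lies within the scatter. Among the measured compounds shown here, this is thin support, since one step sets no pattern and no trifluoromethyl compound has yet been measured. No step beyond the scatter is therefore expected in this assay in either direction. The estimated step is a 1.0-fold higher number from compound 2 to compound 3 (0.01 log units; within the scatter) on this reading. Compound 3 is expected at 700 nM with a likely range from 300 nM to 1600 nM for this estimate.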

Compound 3, half-maximal inhibitory concentration: 560 nM
The estimate for compound 3 lay 1.3-fold (0.10 log units) above the measured number; low and high end bracket the measured number.
By their numbers in this assay, from the lowest: compounds 3, 2 and 1 (each within the scatter of the next).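

In this assay, the change on this aromatic carbon, para to a large group, gives a 1.2-fold lower number from compound 2 to compound 3 (0.08 log units; within the scatter), and the wider comparison with methyl at the same place gives a 1.5-fold lower number from compound 1 to compound 3 (0.17 log units; within the scatter). The earlier step covered only methyl and fluoro, whereas the series now shows that all three pairs among methyl, fluoro and trifluoromethyl lie within the scatter, even though the entering trifluoromethyl has four heavy atoms where fluoro has one. No measurement accompanies these numbers that could account for how closely the three compounds agree.

It remains open whether this flat picture holds for groups of a different kind at this place, such as an amine, a carboxylic acid, a methoxy group or a longer alkyl chain, since the compounds shown carry only methyl, fluoro and trifluoromethyl there. Also open, on these data alone, is how the read-out responds to changes elsewhere on the shared core, which stays the same in compound 1, compound 2 and compound 3.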